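A few compounds are considered here, and "the series" means these few. Any claim that something is new, unique, unknown or untested is made for them only; others in the source may bear on it.

Compound 1 `Cc1ccccc1OS(=O)(=O)c1ccc(N2CCN(C)C2=O)cc1` gives 5600 nM in a functional assay on MCF7 cells (Homo sapiens) for antiproliferative activity, read by sulforhodamine B assay, with a stated time of 48 h; a lower number here means a stronger inhibitor, a higher number a weaker inhibitor. Compound 2 `CN1CCN(c2ccc(S(=O)(=O)Oc3c(Cl)cc(Cl)cc3Cl)cc2)C1=O` gives 2900 nM in this assay. Compound 3 `CCCN1CCN(c2ccc(S(=O)(=O)Oc3ccccc3C)cc2)C1=O` reaches only the limit of > 100000 nM in this assay, so no number is known for it. Among the compounds with values here, the one measured step leading to it, an at least 17-fold higher number from compound 1 to compound 3 (1.25 log units; beyond the scatter), ends at the limit of > 100000 nM in this assay, at which 1 of the 3 values shown sits. Compound 4 `CCCN1CCN(c2ccc(S(=O)(=O)Oc3cccc(Cl)c3)cc2)C1=O` differs from compound 3 in one place: 3-chlorophenyl in place of 2-methylphenyl on an oxygen. Within the data shown here, no measured step bears on this change; compound 1 and compound 2 show what two aryl groups give on the core of compound 1, but the core of compound 3 sits at the limit, so no direction can be read. Compound 4 is therefore expected to remain near that limit, with a step of a number no higher from compound 3 to compound 4 (the limit leaves the size open) and an estimated value of 100000 nM (range 30000 nM to 300000 nM).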

Compound 4, half-maximal inhibitory concentration: 380 nM
Compound 4: the middle estimate sits 260-fold (2.42 log units) above what was measured, and the stated range ends above it.
By their numbers in this assay, from the lowest: compound 4; then compounds 2 and 1 (each within the scatter of the next). At a limit, above all of these: compound 3.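

On the shared core, the group on the oxygen bound to the sulfonyl sulfur decides whether a number is reached at all: in this assay, 3-chlorophenyl in place of 2-methylphenyl gives an at least 260-fold lower number from compound 3 to compound 4 (2.42 log units; beyond the scatter). The core of compound 3 is therefore not tied to the limit. The value of compound 3 is a limit and not a number, so the full size of this step stays open: the limit of > 100000 nM in this assay, at which 1 of the 4 values shown sits.

Within the data shown here, whether the chlorine itself or the place of the substituent carries this step remains open, since the one step changes both. Going by these compounds, what a methoxy group or an amine on that phenyl ring would give is also open.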